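Removing the Protecting Group from the Lactam Nitrogen

The source may report more compounds than this note shows. Statements on the series, on what has been measured and on what is new or still open speak of the compounds shown alone.

Three compounds share one core. Compound 1 `CN(C)CC(=O)N1CCC(NS(=O)(=O)c2cc(S(=O)(=O)c3ccccc3)ccc2C(F)(F)F)CC1` gives 280 nM in a functional assay on U2OS cells for antagonist activity at proto-oncogene Wnt-3 (Homo sapiens), read by a luciferase reporter, with a stated time of 18 h (a lower number here means that less compound is needed, a higher number that more compound is needed for the effect), compound 2 `O=C(CN1CCCC1)N1CCC(NS(=O)(=O)c2cc(S(=O)(=O)c3ccccc3)ccc2C(F)(F)F)CC1` gives 190 nM, and compound 3 `CC(C)(C)OC(=O)N1C(=O)CC[C@H]1C(=O)N1CCC(NS(=O)(=O)c2cc(S(=O)(=O)c3ccccc3)ccc2C(F)(F)F)CC1` gives 90 nM, the lowest number of the three. Going by the values given here, the only measured single-point step, a 1.5-fold lower number from compound 1 to compound 2 (0.17 log units; within the scatter), alters a different part of the molecule and is too small to guide a prediction. Compound 4 `O=C1CC[C@@H](C(=O)N2CCC(NS(=O)(=O)c3cc(S(=O)(=O)c4ccccc4)ccc3C(F)(F)F)CC2)N1` differs from compound 3 by hydrogen in place of tert-butoxycarbonyl on an amide-type nitrogen in a ring. Among the compounds with values here, no measured step touches this position, so the direction of the change cannot be read from the data, and the three measured numbers all lie within a modest span. For compound 4 the expected step is a 1.7-fold higher number from compound 3 to compound 4 (0.22 log units; within the scatter), giving an estimate of 150 nM with a range from 50 nM to 500 nM.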

Compound 4, half-maximal effective concentration: 240 nM
Compound 4: middle estimate off by 1.6-fold (0.20 log units), on the low side; low and high end bracket the measured number.
By their numbers in this assay, from the lowest: compound 3; then compounds 2, 4 and 1 (each within the scatter of the next).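

In this assay, going by these compounds alone, the step at the amide-type nitrogen in the ring is the first measured change at this position, and it lies beyond the scatter: hydrogen in place of tert-butoxycarbonyl gives a 2.7-fold higher number from compound 3 to compound 4 (0.43 log units; beyond the scatter) here. Without that group, the 5-oxopyrrolidin-2-yl compound no longer stands apart from the compounds with basic-free naming aside, those carrying (pyrrolidin-1-yl)methyl (a 1.3-fold higher number from compound 2 to compound 4 (0.10 log units; within the scatter)) or (dimethylamino)methyl (a 1.2-fold lower number from compound 1 to compound 4 (0.07 log units; within the scatter)), both within the scatter. Nothing available explains the step. Going by these compounds, whether a smaller group on this nitrogen, such as methyl or acetyl, would match tert-butoxycarbonyl remains open.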